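The source may report more compounds than this note shows. Statements on the series, on what has been measured and on what is new or still open speak of the compounds shown alone.

Compound 1 `CO[C@@H]1[C@H](N(C)c2ncc(-c3c[nH]c4ccc(F)cc34)s2)C[C@H]2O[C@]1(C)n1c3ccccc3c3c4c(c5c6cc(Cl)ccc6n2c5c31)C(=O)NC4` and compound 2 `CO[C@@H]1[C@H](N(C)c2ncc(-c3c[nH]c4ccc(Cl)cc34)s2)C[C@H]2O[C@]1(C)n1c3ccccc3c3c4c(c5c6cc(Cl)ccc6n2c5c31)C(=O)NC4` share one core and differ in a single halogen. In a functional assay on MV4-11 cells (Homo sapiens) for antiproliferative activity, read by CellTiter-Glo, with a stated time of 72 h (on this read-out lower numbers stand for stronger inhibition and higher numbers for weaker inhibition), compound 1 gives 320 nM. In the same this assay compound 2 gives 590 nM. Among the measured compounds shown here, the only measured step in this set is a 1.8-fold higher number from compound 1 to compound 2 (0.27 log units; within the scatter). Compound 2 therefore carries the higher of the two numbers recorded so far, but its gap to compound 1 lies within the scatter, so the two cannot be separated on these data.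

Compound 3 `COc1ccc2[nH]cc(-c3cnc(N(C)[C@@H]4C[C@H]5O[C@@](C)([C@@H]4OC)n4c6ccccc6c6c7c(c8c9cc(Cl)ccc9n5c8c64)C(=O)NC7)s3)c2c1` is the next member. Its change from compound 2 is methoxy in place of chloro on an aromatic carbon. For the measured compounds named here, no measured step replaces a halogen with a methoxy group, so there is no direct precedent. Going by the values given here, the one step that touches the same position, a 1.8-fold higher number from compound 1 to compound 2 (0.27 log units; within the scatter), stayed within the scatter, which suggests that a change at this position need not move the number far. On that basis the step expected for compound 3 is a 1.2-fold lower number from compound 2 to compound 3 (0.07 log units; within the scatter), no larger than the scatter. The estimate for compound 3 is 500 nM, expected to fall between 180 nM and 1400 nM.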

Compound 3, half-maximal inhibitory concentration: 440 nM
Estimate against measurement, compound 3: 1.1-fold (0.06 log units) above; low and high end bracket the measured number.
By their numbers in this assay, from the lowest: compounds 1, 3 and 2 (each within the scatter of the next).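

Among the compounds shown here, until now, the only change at this aromatic carbon of the indole had been one halogen for another. Compound 3 extends the comparison to methoxy, which brings in oxygen and a hydrogen-bond acceptor, yet in this assay the step of a 1.3-fold lower number from compound 2 to compound 3 (0.13 log units; within the scatter) and the step of a 1.4-fold higher number from compound 1 to compound 3 (0.14 log units; within the scatter) both remain as small as the step between the two halogens. Fluoro, chloro and methoxy at this carbon therefore cannot be separated on these numbers, and the data shown offer no measurement that would account for this lack of separation.

As far as these compounds go, it remains open whether any group at this carbon can move the number beyond the scatter, for instance an amine, a carboxylic acid, a longer chain such as ethoxy, or plain hydrogen in place of the substituent. The three compounds also share the rest of the structure, so they leave open whether changes elsewhere on the shared core, such as to the chloro group it carries, would shift the number further than any change seen here.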